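Does Flipping One Double Bond Change the Reading?

The source may report more compounds than this note shows. Statements on the series, on what has been measured and on what is new or still open speak of the compounds shown alone.

In a functional assay on the whole organism for cytotoxicity, with Mus musculus as the target (a higher number here means a weaker inhibitor, a lower number a stronger inhibitor), compound 1 `NC1=NC(N)c2c(ncn2C=C=CCO)N1` gives 255000 nM, and a lower number would mean a stronger effect. Compound 2 `Nc1ncnc2c1ncn2/C=C\CCO` is reported as > 300000 nM, which is a limit of the assay and not a number. Compound 2 therefore stands at the limit of > 300000 nM in this assay, at which 1 of the 2 values shown sits.

The next compound is compound 3 `Nc1ncnc2c1ncn2/C=C/CCO`, and its structure differs very little: the two compounds have the same atoms and bonds and differ only in configuration as drawn: 1 of 1 stereo elements differ; a double bond is drawn Z in compound 2 and E in compound 3. In short, a double bond is drawn Z in compound 2 and E in compound 3. Going by the values given here, no measured pair yet shows what such a change does in this assay, so no change beyond the usual scatter is expected. The expected size of the step of a number no higher from compound 2 to compound 3 (the limit leaves the size open) is therefore small. For compound 3 the estimated value is 300000 nM, with an expected range of 150000 nM to 600000 nM.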

Compound 3, half-maximal inhibitory concentration: 304000 nM
Compound 3: the middle estimate sits 1.0-fold (0.01 log units) below what was measured; the measured number falls inside the stated range.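

No step can be read between compound 2 and compound 3, because compound 2 carries a limit of the assay and not a number: the limit of > 300000 nM in this assay, at which 1 of the 3 values shown sits.

The compounds shown leave open whether drawing the double bond Z or E changes the reading in this assay at all.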